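Compound 4: a chlorophenyl swap at a weak end

The source may report more compounds than this note shows. Statements on the series, on what has been measured and on what is new or still open speak of the compounds shown alone.

Measured in a functional assay on HT-29 cells (Homo sapiens) for inhibition, read by CCK-8 assay, with a stated time of 24 h; on this read-out lower numbers stand for stronger inhibition and higher numbers for weaker inhibition:
- Compound 1 `O=C1Nc2ccccc2/C1=C/c1ccc(-c2cn(-c3ccccc3Cl)nn2)cc1`: > 20000 nM (a limit)
- Compound 2 `Cc1cccc(-n2cc(-c3ccc(/C=C4\C(=O)Nc5ccc(F)cc54)cc3)nn2)c1`: 7320 nM
- Compound 3 `O=C1Nc2ccc(F)cc2/C1=C/c1ccc(-c2cn(-c3ccc(F)cc3)nn2)cc1`: 20000 nM

Of the two exact numbers in this assay, the higher belongs to compound 3, at 20000 nM. Going by the values given here, the only measured step is a 2.7-fold higher number from compound 2 to compound 3 (0.44 log units; beyond the scatter), with 4-fluorophenyl in place of 3-methylphenyl on an aromatic nitrogen. Compound 1 carries a 2-chlorophenyl group, and its result of > 20000 nM is a limit, not a number.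

Compound 4 `O=C1Nc2ccc(F)cc2/C1=C/c1ccc(-c2cn(-c3ccccc3Cl)nn2)cc1` has not yet been measured. It has 2-chlorophenyl in place of 4-fluorophenyl on an aromatic nitrogen, on a five-membered aromatic ring with 3 nitrogen. Among the compounds with values here, no measured step makes this exact exchange. The step from compound 2 to compound 3 changes the group at the same place and is modest, so a large shift is not expected here. The limit seen with compound 1 suggests that a weak result is likely, and compound 4 may also give only a limit. The expected change is therefore none beyond the scatter, with an estimated step of a 1.3-fold lower number from compound 3 to compound 4 (0.10 log units; within the scatter). For compound 4 the estimated value is 16000 nM, with an expected range from 7000 nM to 35000 nM.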

Compound 4, half-maximal inhibitory concentration: 5950 nM
The estimate for compound 4 lay 2.7-fold (0.43 log units) above the measured number, outside the stated range (below it).
By their numbers in this assay, from the lowest: compounds 4 and 2 (each within the scatter of the next); then compound 3.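

In this assay, the group on the aromatic nitrogen of the five-membered ring proves able to move the number in the stronger direction as well as the weaker: 2-chlorophenyl in place of 4-fluorophenyl gives a 3.4-fold lower number from compound 3 to compound 4 (0.53 log units; beyond the scatter). 2-Chlorophenyl in place of 3-methylphenyl gives a 1.2-fold lower number from compound 2 to compound 4 (0.09 log units; within the scatter), so these two groups cannot be told apart here, and among the three groups compared on the fluorinated core only 4-fluorophenyl stands apart. The new compound also gives a first reading of the fluoro group on the core, fluoro in place of hydrogen on an aromatic carbon with 2-chlorophenyl held constant, as an at least 3.3-fold lower number from compound 1 to compound 4 (0.52 log units; beyond the scatter); that step rests on the result for compound 1, which is a limit and not a number: the limit of > 20000 nM in this assay, at which 1 of the 4 values shown sits.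

The compounds shown cannot separate the chlorine from its place on the ring, and how 4-chlorophenyl or 2-fluorophenyl would read on the same core stays open. Also open, from the compounds shown here alone, is whether a group of another kind on that nitrogen, such as a pyridine ring or a benzyl group, would carry the number further in either direction.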